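The source may hold more compounds than are shown below. What is called first, only, known or untested is meant among the compounds shown, and "the series" means these compounds.

The shared core, shown in compound 1 `CC1=NNC(=O)C1C(c1c(-c2ccccc2)[nH]c2ccc(C)cc12)c1c(-c2ccccc2)[nH]c2ccc(Cl)cc12`, carries two fused ring systems whose substituents vary across the set. In a functional assay on HEp-2 cells (Homo sapiens) for cytotoxicity, read by MTT assay (on this read-out higher numbers stand for weaker inhibition and lower numbers for stronger inhibition), compound 1 gives 32400 nM. Compound 2 `CC1=NNC(=O)C1C(c1c(-c2ccccc2)[nH]c2ccccc12)c1c(-c2ccccc2)[nH]c2ccc(C)cc12` reaches only a limit of the assay, > 100000 nM, and no number. Compound 3 `CC1=NNC(=O)C1C(c1c[nH]c2ccccc12)c1c(-c2ccccc2)[nH]c2ccc(C)cc12` gives 3200 nM in this assay, the lowest of the two numbers recorded, with compound 1 standing well above it, a gap beyond the scatter.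

Two measured steps frame the change. Hydrogen in place of chloro on an aromatic carbon gave an at least 3.0-fold higher number from compound 1 to compound 2 (0.48 log units; beyond the scatter), although that end rests at the limit (the limit of > 100000 nM in this assay, at which 1 of the 3 values shown sits). Hydrogen in place of phenyl on an aromatic carbon gave an at least 31-fold lower number from compound 2 to compound 3 (1.49 log units; beyond the scatter).

Compound 4 `CC1=NNC(=O)C1C(c1c[nH]c2ccccc12)c1c(-c2ccccc2)[nH]c2ccccc12` differs from compound 3 by hydrogen in place of methyl on an aromatic carbon. Within the data shown here, no measured step removes a methyl, and the stripping of phenyl is far larger in kind. The nearest parallel is the loss of chloro from compound 1 to compound 2, which raised the number. A modest rise, near the edge of the scatter, is therefore expected for compound 4, a 1.9-fold higher number from compound 3 to compound 4 (0.27 log units; within the scatter). Compound 4 is estimated at 6000 nM in this assay, within a range from 2500 nM to 15000 nM.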

Compound 4, half-maximal inhibitory concentration: 6700 nM
Estimate against measurement, compound 4: 1.1-fold (0.05 log units) below; the range from low to high includes it.
By their numbers in this assay, from the lowest: compound 3; then compound 4; then compound 1. At a limit, above all of these: compound 2.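

In this assay, the loss of methyl from the six-membered aromatic ring, at the place meta to a fused ring and para to a fused ring, gave a 2.1-fold higher number from compound 3 to compound 4 (0.32 log units; beyond the scatter), so this position responds to even the smallest change shown, and the step is modest in size with a measured number at both ends. Its direction matches the loss of chloro in an at least 3.0-fold higher number from compound 1 to compound 2 (0.48 log units; beyond the scatter), though that step rests on a limit, and the loss of phenyl goes against this direction, with an at least 31-fold lower number from compound 2 to compound 3 (1.49 log units; beyond the scatter). Nothing given here accounts for the step from methyl to hydrogen.

As far as these compounds go, it remains open how a methoxy group, an amine or a carboxylic acid at this position would read in this assay, and whether a longer chain such as propyl would extend the trend seen with methyl and hydrogen or reverse it. From the compounds shown here alone, it is also open whether the same loss of methyl would give a step of similar size on a compound that keeps phenyl on both fused ring systems, as compound 1 does.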